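Ring Size of the Amide Piece and Cell Toxicity

The source may report more compounds than this note shows. Statements on the series, on what has been measured and on what is new or still open speak of the compounds shown alone.

Compound 1 `O=C(Nc1ccc2sc(-c3ccccc3F)nc2c1)N1CCCCC1`: in an ADME assay on HepG2 cells (Homo sapiens) for inhibition, read by resazurin assay, with a stated time of 48 h (on this read-out lower numbers stand for an effect already at smaller amounts and higher numbers for an effect only at larger amounts of compound), compound 1 gives > 50 uM, which is a limit of the assay rather than a number.
Compound 2 `O=C(Nc1ccc2sc(-c3cccc(F)c3)nc2c1)N1CCCC1`: compound 2 gives > 50 uM, again a limit.
Compound 3 `O=C(Nc1ccc2sc(-c3ccc(F)cc3)nc2c1)N1CCCC1`: compound 3 gives > 50 uM, also a limit.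

Compound 3 thus stands at the limit, where every value shown sits (the limit of > 50 uM in this assay, at which 3 of the 3 values shown sit). For the measured compounds named here, the one measured step, a step that the two limits leave unreadable from compound 2 to compound 3, runs between two limits and gives no readable size. Compound 4 `O=C(Nc1ccc2sc(-c3ccc(F)cc3)nc2c1)N1CCCCC1` differs from compound 3 by piperidin-1-yl in place of pyrrolidin-1-yl on a carbonyl carbon. Going by the values given here, no measured step covers this change. Compound 1 also carries piperidin-1-yl, and its value is a limit. Compound 4 is therefore expected to remain at the limit, with an expected step that the limit leaves unreadable from compound 3 to compound 4, within scatter. The estimate for compound 4 is 80 uM, ranging from 40 uM to 200 uM.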

Compound 4, concentration for 90% of the maximal effect: > 50 uM
Compound 4 gave a limit, no number (the forecaster's own chance of this, stated with the estimate: 85%); the middle value is on the limit's open side.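

Compound 4 sits at a limit, like compounds 1 and 3, so its steps from both cannot be read: the limit of > 50 uM in this assay, at which 4 of the 4 values shown sit.

The compounds shown leave open whether piperidin-1-yl and pyrrolidin-1-yl differ at all in this assay.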